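Halogen Swap on the Phenyl Analogue Toward Compound 4

The source may report more compounds than this note shows. Statements on the series, on what has been measured and on what is new or still open speak of the compounds shown alone.

Of the compounds shown here, three have been measured in an assay on isolated protein for inhibition of Calpain-1 catalytic subunit (Sus scrofa), read by FRET; on this read-out lower numbers stand for stronger inhibition and higher numbers for weaker inhibition. Compound 1 `O=C(O)/C(S)=C/c1c[nH]c2cc(Br)ccc12` gives 7 nM and compound 3 `O=C(O)/C(S)=C/c1c[nH]c2cccc(Br)c12` gives 6 nM. Compound 2 `O=C(O)/C(S)=C/c1ccc(I)cc1` gives 2200 nM, the highest of the three numbers, and its gaps to compound 1 and to compound 3 both lie beyond the scatter. Compound 4 `O=C(O)/C(S)=C/c1ccc(Cl)cc1` differs from compound 2 by chloro in place of iodo on an aromatic carbon, para to a group of 6 heavy atoms. Among the measured compounds shown here, no measured pair shows such a halogen exchange, so the author expects no step beyond the scatter, a 1.4-fold higher number from compound 2 to compound 4 (0.13 log units; within the scatter), with a slight lean toward a higher number. Compound 4 is thus expected to give 3000 nM, within 1000 nM to 9000 nM.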

Compound 4, half-maximal inhibitory concentration: 2600 nM
Compound 4: middle estimate off by 1.2-fold (0.06 log units), on the high side, and the stated range covers the measured number.
By their numbers in this assay, from the lowest: compounds 3 and 1 (each within the scatter of the next); then compounds 2 and 4 (each within the scatter of the next).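

In this assay, chloro in place of iodo on an aromatic carbon, para to a group of 6 heavy atoms, gives a 1.2-fold higher number from compound 2 to compound 4 (0.07 log units; within the scatter) and provides the first pair differing in one place. At this position, the two halogens cannot be told apart. No measurement here offers an explanation for this outcome.

From the compounds shown here alone, whether fluoro, an amine or a carboxylic acid at the same place would leave the number within the scatter remains open. So does whether the same halogen exchange would behave alike on another core.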